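This account rests on a few compounds, and the source may have more. Where it says the series, first, only, none or still open, it means among the compounds named here.

Working notes on the series, solubility set.

Compound 1 `COc1ccc2[nH]c(C(=O)N3CC(=O)N(Cc4cccc(OC(F)F)c4)[C@@H](CN4CCC(C#N)CC4)C3)cc2c1` is the reference point. In a physicochemical assay for solubility, read by spectrophotometry, in phosphate buffer, with a stated time of 2 h, at pH 7.4 (a higher number here means a more soluble compound, a lower number a less soluble compound), compound 1 gives 27900 nM, the highest of the two numbers recorded. Within the data shown here, compound 2 `O=C(c1cc2cc(C3CC3)ccc2[nH]1)N1CC(=O)N(Cc2ccccc2)[C@@H](CN2CCC(F)CC2)C1`, the only other compound with a number, gives 12400 nM in this assay, which sits beyond the scatter from compound 1. Compound 3 `COc1ccc2[nH]c(C(=O)N3CC(=O)N(Cc4ccccc4)[C@@H](CN4CCN(Cc5ccccn5)CC4)C3)cc2c1` returns only a limit in this assay, > 100000 nM, and no number. One of the three results therefore sits at the limit of this assay (the limit of > 100000 nM in this assay, at which 1 of the 3 values shown sits), so the numerical spread of the series is known from two compounds only.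

Compound 4 `COc1ccc2[nH]c(C(=O)N3CC(=O)N(Cc4cccc(OC(F)F)c4)[C@@H](CN4CCC(c5ccccn5)CC4)C3)cc2c1` has not yet been measured. It differs from compound 1 in one place: pyridin-2-yl in place of cyano on a saturated ring carbon. Among the measured compounds shown here, no measured pair follows this same change, so the expected size of the step rests on the structural change alone. A modest decrease in solubility is expected for compound 4 relative to compound 1, a step of about a 2.1-fold lower number from compound 1 to compound 4 (0.33 log units; beyond the scatter), near the edge of the scatter rather than far beyond it. The estimate for compound 4 in this assay is 13000 nM, with a range from 3500 nM to 50000 nM; the measurement is awaited.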

Compound 4, solubility: 11600 nM
Estimate against measurement, compound 4: 1.1-fold (0.05 log units) above, and the stated range covers the measured number.
By their numbers in this assay, from the lowest: compounds 4 and 2 (each within the scatter of the next); then compound 1. At a limit, above all of these: compound 3.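

In this assay, among these compounds, this is the first step that can be read at this position, on a saturated ring carbon of the six-membered non-aromatic ring with 1 nitrogen, three ring bonds from the ring nitrogen: pyridin-2-yl in place of cyano gives a 2.4-fold lower number from compound 1 to compound 4 (0.38 log units; beyond the scatter), a modest step beyond the scatter. The change replaces 2 heavy atoms and a triple bond with 6 heavy atoms and a six-membered aromatic ring, while hydrogen-bond donors, hydrogen-bond acceptors and net charge stay the same in count, so a much larger group at this position still leaves compound 4 with a measured number rather than a limit. Nothing measured for these compounds accounts for the size of the step.

From the compounds shown here alone, how phenyl or a carboxylic acid on the same saturated ring carbon would compare with compound 1 stays open, as does whether the step from cyano to pyridin-2-yl carries over when the other parts of the molecule differ. Compound 3 returns a limit and not a number, so the upper end of the series stays undefined: the limit of > 100000 nM in this assay, at which 1 of the 4 values shown sits.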